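The source may hold more compounds than are shown below. What is called first, only, known or untested is meant among the compounds shown, and "the series" means these compounds.

In a functional assay on HL-60 cells (Homo sapiens) for cytotoxicity, read by MTT assay, with a stated time of 72 h (a higher number here means a weaker inhibitor, a lower number a stronger inhibitor), compound 1 `CC1=C(CC[C@@H](C)C(=O)CCC2=CC(=O)OC2)C(C)(C)CCC1` gives < 5 ug/mL, a limit of the assay rather than a number. Compound 2 `CC(=O)O[C@@H]1C[C@@H](C)[C@]2(CC[C@]3(COC(=O)C3)O2)[C@@]2(C)CCCC(C)(C)[C@H]12` likewise reaches only the assay limit, giving < 5 ug/mL. Compound 2 thus stands at the limit of < 5 ug/mL in this assay, at which 2 of the 2 values shown sit, so no number is available to build on. Compound 3 `C[C@@H]1C[C@@H](O)[C@H]2C(C)(C)CCC[C@]2(C)[C@@]12CC[C@]1(COC(=O)C1)O2` differs from compound 2 by hydrogen in place of acetyl on an oxygen on a saturated carbon. Among the measured compounds shown here, no measured step covers this change; in this assay a shift toward weaker inhibition is expected, likely within or just beyond the scatter. The expected step from compound 2 to compound 3 is a number no lower from compound 2 to compound 3 (the limit leaves the size open). Compound 3 is estimated at 5 ug/mL, with a range from 1 ug/mL to 25 ug/mL.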

Compound 3, half-maximal inhibitory concentration: < 5 ug/mL
Compound 3 ended at the assay's limit; the forecaster's own chance of this, stated with the estimate: 50%; the middle value lies on the limit itself.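

No step can be read between compound 2 and compound 3 in this assay because both values are limits rather than numbers: the limit of < 5 ug/mL in this assay, at which 3 of the 3 values shown sit. The compounds shown leave open how far, and in which direction, acetoxy to hydroxy moves the potency.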